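The source may report more compounds than this note shows. Statements on the series, on what has been measured and on what is new or still open speak of the compounds shown alone.

Measured so far in an ADME assay on microsomes from liver (Mus musculus) for metabolic stability, read by LC-MS, with a stated time of 10 min, tested at 0.5 uM; a higher number here means that more of the compound is left, a lower number that less of the compound is left:

Compound 1 `c1ccc2c(c1)CN[C@H](CN(CCCN1CCNCC1)[C@H]1CCCc3cccnc31)C2` gives 88%
Compound 2 `c1ccc2c(c1)CN[C@@H](CN(CC[C@@H]1CCCNC1)[C@H]1CCCc3cccnc31)C2` gives 23%
Compound 3 `CN1CCN(CCCN(C[C@H]2Cc3ccccc3CN2C)[C@H]2CCCc3cccnc32)CC1` gives 43%

Compound 2 holds the lowest of these three numbers, so less of it is left than of either other compound. Its gaps to compound 3 and to compound 1 both lie beyond the usual scatter of repeated measurements.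

The next compound to be tested is compound 4 `CCN1CCN(CCCN(C[C@H]2Cc3ccccc3CN2)[C@H]2CCCc3cccnc32)CC1` and it differs from compound 2 by the change (4-ethylpiperazin-1-yl)methyl in place of piperidin-3-yl on a saturated chain carbon, two bonds along the chain from an amine nitrogen with (4-ethylpiperazin-1-yl)methyl in place of piperidin-3-yl on a saturated chain carbon, two bonds along the chain from an amine nitrogen.

For the measured compounds named here, no measured pair of compounds shows this exact change, so any forecast is only a rough one. The nearest guides are the two compounds with a piperazine in their side chain. Compound 1 gives 88% and compound 3 gives 43% in this assay and both numbers sit well above that of compound 2, though far apart from each other. A rise is therefore expected, and the estimated a number 37 percentage points higher from compound 2 to compound 4 (beyond the scatter) would lie beyond the scatter. For compound 4 the expected value is 60% with an estimated range from 35% to 82% in this wide window.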

Compound 4, percent of the compound remaining: 19%
For compound 4 the middle estimate is 41 percentage points above the measured one, and the stated range ends above it.
By their numbers in this assay, from the lowest: compounds 4 and 2 (each within the scatter of the next); then compound 3; then compound 1.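

In this assay, the exchange of piperidin-3-yl for (4-ethylpiperazin-1-yl)methyl gives a number 4 percentage points lower from compound 2 to compound 4 (within the scatter). For the compounds shown here, this is the first comparison in the set that changes a single place, and it shows that a larger group of 9 heavy atoms in place of 6 leaves no readable shift in the share of compound remaining. A piperazine ring in the side chain does not by itself go with a high number: compound 4 carries such a ring and gives 19%, while compound 1, which also carries one, gives 88%.

The data shown hold no measurement that speaks to why compound 2 and compound 4 stand so close. From the compounds shown here alone, it stays open what the ethyl group on the piperazine contributes to this result, and how a 2-hydroxyethyl or acetyl group on that ring nitrogen, or a morpholine ring in place of the piperazine, would read in this assay.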